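Moving a hydroxyl group on a hydroxyphenyl ring

A few compounds are considered here, and "the series" means these few. Any claim that something is new, unique, unknown or untested is made for them only; others in the source may bear on it.

Compound 2 `Oc1ccccc1-c1cc(-c2cccnc2)cc(-c2ccccc2O)n1` is one of two compounds examined in a functional assay on T47D cells (Homo sapiens) for cytotoxicity, read by CCK-8 assay; a lower number here means a stronger inhibitor, a higher number a weaker inhibitor. Compound 2 reaches only the limit of the measurement, > 50000 nM. Compound 1 `Oc1cccc(-c2cc(-c3ccoc3)cc(-c3ccccc3O)n2)c1` likewise gives only a limit, > 50000 nM. Both sit at the limit of > 50000 nM in this assay, at which 2 of the 2 values shown sit, so no numbered value exists for either. Compound 3 `Oc1cccc(-c2cc(-c3cccnc3)cc(-c3ccccc3O)n2)c1` differs from compound 2 by 3-hydroxyphenyl in place of 2-hydroxyphenyl on an aromatic carbon, placed next to the ring nitrogen. Among the measured compounds shown here, no step between measured compounds is recorded, and two limits give no hint of direction, so the change from compound 2 to compound 3 is expected to stay within the scatter, a step that the limit leaves unreadable from compound 2 to compound 3. Compound 3 is estimated at 70000 nM, between 20000 nM and 250000 nM, most likely again only a limit.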

Compound 3, half-maximal inhibitory concentration: 6230 nM
For compound 3 the middle estimate is 11-fold (1.05 log units) above the measured one, and the stated range ends above it.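

In this assay, the position of the hydroxyl group on this ring matters: 3-hydroxyphenyl in place of 2-hydroxyphenyl gives an at least 8.0-fold lower number from compound 2 to compound 3 (0.90 log units; beyond the scatter). With 3-hydroxyphenyl present in both compounds, the other ring substituent matters too: pyridin-3-yl in place of furan-3-yl gives an at least 8.0-fold lower number from compound 1 to compound 3 (0.90 log units; beyond the scatter). Both steps are minimum sizes, since each starting compound gives only a limit: the limit of > 50000 nM in this assay, at which 2 of the 3 values shown sit.

The compounds shown leave open whether 4-hydroxyphenyl at this place would give a lower number. They also leave open whether the hydroxyl group itself is needed, which a methoxy group or an amine in its place could test.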